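Cyclopentyl gives way to 1-methoxyethyl in compound 4

The source may report more compounds than this note shows. Statements on the series, on what has been measured and on what is new or still open speak of the compounds shown alone.

In a functional assay on OCI-Ly3 cells (Homo sapiens) for antiproliferative activity (on this read-out higher numbers stand for an effect only at larger amounts of compound and lower numbers for an effect already at smaller amounts), compound 1 `Cc1c(NC(=O)Nc2cnc(-n3nccn3)c(Cl)c2)cnc2ccc(Br)cc12` gives 12900 nM, compound 2 `Cc1c(NC(=O)Nc2cnc(-n3nccn3)c(Cl)c2)cnc2ccccc12` gives 7170 nM and compound 3 `O=C(Nc1cnc(-n2nccn2)c(Cl)c1)Nc1cnc2ccccc2c1C1CCCC1` gives 7020 nM. These three values lie within the scatter of one another, so compound 3 cannot be told apart from either of the other two.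

The next structure, compound 4 `COC(C)c1c(NC(=O)Nc2cnc(-n3nccn3)c(Cl)c2)cnc2ccccc12`, carries 1-methoxyethyl in place of cyclopentyl on an aromatic carbon. The measured step that bears most directly on this change is a 1.0-fold lower number from compound 2 to compound 3 (0.01 log units; within the scatter), with cyclopentyl in place of methyl on that same carbon, and it stays within the scatter. The other step, a 1.8-fold lower number from compound 1 to compound 2 (0.26 log units; within the scatter), has hydrogen in place of bromo at a different place on the core, so it bears only loosely, and it too stays within the scatter. For the measured compounds named here, no measured compound carries a group with oxygen at the carbon in question, so that part of the change remains untested, and the range has to stay wide. An estimated 1.1-fold higher number from compound 3 to compound 4 (0.03 log units; within the scatter) is expected, which means no step beyond the scatter in this assay. Compound 4 is estimated at 7500 nM, with an expected range from 3500 nM to 16000 nM.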

Compound 4, half-maximal effective concentration: 620 nM
For compound 4 the middle estimate is 12-fold (1.08 log units) above the measured one; the whole stated range lies above it.
By their numbers in this assay, from the lowest: compound 4; then compounds 3, 2 and 1 (each within the scatter of the next).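

At this position, opposite the ring nitrogen, this assay turns out to respond strongly to the group present: 1-methoxyethyl in place of cyclopentyl gives an 11-fold lower number from compound 3 to compound 4 (1.05 log units; beyond the scatter) and 1-methoxyethyl in place of methyl on the same carbon gives a 12-fold lower number from compound 2 to compound 4 (1.06 log units; beyond the scatter) in the same read-out. Methyl and cyclopentyl had given numbers within the scatter of each other, so the earlier compounds showed no response to the group at this carbon, and the first clear separation comes with compound 4, whose group is the only one here to hold an oxygen and a hydrogen-bond acceptor. Nothing available explains why this change has so large an effect.

How an isopropyl, a 1-hydroxyethyl or a methoxymethyl group would behave at this carbon remains open, so the compounds shown do not separate the part played by the oxygen from that of the branched chain. Also open, on these data alone, are whether the two mirror-image forms of 1-methoxyethyl differ and whether the lower number carries over to the bromo-bearing core of compound 1.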